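This account rests on a few compounds, and the source may have more. Where it says the series, first, only, none or still open, it means among the compounds named here.

Of the compounds shown here, two have been measured in a functional assay on MDA-MB-231 cells (Homo sapiens) for antiproliferative activity, read by MTT assay, with a stated time of 48 h (a lower number here means a stronger inhibitor, a higher number a weaker inhibitor), and they give one limit and one number. Compound 1 `COc1ccc(-n2cc(COC(=O)/C(C)=C/CC/C(C)=C/CC/C(C)=C/CC[C@@H]3[C@@]4(C)CCC(=O)C(C)(C)[C@H]4CC[C@@]3(C)O)nn2)cc1` is reported at > 150000 nM, which is a limit of the assay and not a number. Compound 2 `C/C(=C\CC/C(C)=C/CC[C@@H]1[C@@]2(C)CCC(=O)C(C)(C)[C@H]2CC[C@@]1(C)O)CC/C=C(\C)C(=O)OCc1cn([C@@H]2C[C@@H](n3cc(C)c(=O)[nH]c3=O)O[C@H]2CO)nn1` gives a measured 38000 nM.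

Compound 3 `C/C(=C\CC/C(C)=C/CC[C@@H]1[C@@]2(C)CCC(=O)C(C)(C)[C@H]2CC[C@@]1(C)O)CC/C=C(\C)C(=O)OCc1cn(-c2cccc(C(F)(F)F)c2)nn1` departs from compound 1 at a single place, with 3-(trifluoromethyl)phenyl in place of 4-methoxyphenyl on an aromatic nitrogen of a five-membered aromatic ring with 3 nitrogen: 3-(trifluoromethyl)phenyl in place of 4-methoxyphenyl on an aromatic nitrogen. The rest of the molecule, including the shared core and the ester chain, is unchanged.

With only a limit for compound 1, the data set no firm size for this step. Among the measured compounds shown here, the only number available is that of compound 2 at 38000 nM, so a measurable result is expected to be possible. A second limit could also be returned for compound 3. The expected change in this assay is a small one toward stronger inhibition, an at least 1.6-fold lower number from compound 1 to compound 3 (0.22 log units; that floor lies within the scatter), and it may not clear the usual scatter. For compound 3 the half-maximal inhibitory concentration is estimated at 90000 nM, within an expected range of 35000 nM to 200000 nM.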

Compound 3, half-maximal inhibitory concentration: > 150000 nM
Compound 3 ended at the assay's limit (the forecaster's own chance of this, stated with the estimate: 45%); at least 1.6-fold (0.22 log units) between middle value and limit.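

No step can be read from compound 1 to compound 3, since both stand only as limits in this assay: the limit of > 150000 nM in this assay, at which 2 of the 3 values shown sit.

The compounds shown leave open whether 3-(trifluoromethyl)phenyl or 4-methoxyphenyl on the aromatic nitrogen gives the stronger inhibitor, or whether the two differ at all.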